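The compounds below may be only part of what the source reports. "The series", "measured", "known", "first", "only" and "open" are said of these compounds alone.

Two compounds sharing one core, compound 1 `C=C1C(=O)[C@]23C[C@@]1(O)CC[C@H]2c1ccc(OS(=O)(=O)c2ccc(C)cc2)c(C)c1[C@@H]3Cn1cc(-c2ccccn2)nn1` and compound 2 `C=C1C(=O)[C@]23C[C@@]1(O)CC[C@H]2c1ccc(OS(=O)(=O)c2ccc(C)cc2)c(C)c1[C@@H]3Cn1cc(-c2ccc(Br)cc2)nn1`, were tested in a functional assay on A549 cells (Homo sapiens) for cytotoxicity, read by MTT assay, with a stated time of 4 days; a lower number here means a stronger inhibitor, a higher number a weaker inhibitor. Compound 1 gives 2310 nM, and compound 2 gives 1630 nM. The two differ only in that compound 1 carries pyridin-2-yl in place of 4-bromophenyl on an aromatic carbon, and the change made a 1.4-fold higher number from compound 2 to compound 1 (0.15 log units; within the scatter), so the two values cannot be told apart.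

Compound 3 `C=C1C[C@]23C[C@@]1(O)CC[C@@H]2c1cccc(C)c1[C@@H]3Cn1cc(-c2ccc(Br)cc2)nn1` rests on a different core; how that core differs from the core of compound 2 is not broken down here. In this assay compound 3 reaches only a limit of the assay, > 20000 nM.

Compound 4 `C=C1C[C@]23C[C@@]1(O)CC[C@@H]2c1cccc(C)c1[C@@H]3Cn1cc(-c2ccccn2)nn1` has not yet been measured. It stands to compound 3 exactly as compound 1 stands to compound 2: the difference is pyridin-2-yl in place of 4-bromophenyl on an aromatic carbon, the same change at the same place. Since that change left the values of compound 2 and compound 1 within the scatter, the author expects it to move compound 3 little, a step that the limit leaves unreadable from compound 3 to compound 4 in this assay. Because compound 3 sits at the limit of > 20000 nM in this assay, at which 1 of the 3 values shown sits, compound 4 is expected to land near 30000 nM, most likely again as a limit rather than a number. Should a number be obtained, the estimate runs from 10000 nM to 100000 nM for compound 4.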

Compound 4, half-maximal inhibitory concentration: > 20000 nM
Compound 4: a limit, no number; the forecaster's own chance of this, stated with the estimate: 75%; the middle value is on the limit's open side.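

In this assay, compound 3 and compound 4 both reach only a limit of the assay, so no step between them can be read: the limit of > 20000 nM in this assay, at which 2 of the 4 values shown sit.

The compounds shown leave open whether pyridin-2-yl in place of 4-bromophenyl makes any difference on the core of compound 3, and which feature separating that core from the core of compound 2 matters in this assay.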